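Methoxy in Place of Chloro: Compound 4 Expected at Limit

The compounds below may be only part of what the source reports. "The series", "measured", "known", "first", "only" and "open" are said of these compounds alone.

Measured compounds: compound 1 `CCOc1ccccc1NC(=O)CSc1c[nH]c2c(Br)c(OC)ccc12` gives > 100000 nM in an ADME assay on HEK-293T cells (Homo sapiens) for cytotoxicity, read by CCK-8 assay, with a stated time of 48 h; a lower number here means that less compound is tolerated, a higher number that more compound is tolerated. Compound 2 `O=C(CSc1c[nH]c2c(Cl)cccc12)Nc1ccc(Cl)c(Cl)c1` gives 49100 nM. Compound 3 `CCOc1ccccc1NC(=O)CSc1c[nH]c2cc(Cl)ccc12` gives > 100000 nM.

For compound 3 the value in this assay is a limit of the assay, not a number. The same holds for compound 1, whose value is also a limit. Compound 2 alone gives a number. Compound 3 thus stands at the limit of > 100000 nM in this assay, at which 2 of the 3 values shown sit.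

Compound 4 `CCOc1ccccc1NC(=O)CSc1c[nH]c2cc(OC)ccc12` differs from compound 3 by methoxy in place of chloro on an aromatic carbon, in words methoxy in place of chloro on an aromatic carbon. For the measured compounds named here, no measured pair shows this change, so no step size is known. The expected step of a number no higher from compound 3 to compound 4 (the limit leaves the size open) is none beyond the scatter. Compound 4 is therefore expected at 100000 nM, with a range from 40000 nM to 250000 nM.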

Compound 4, half-maximal cytotoxic concentration: 88200 nM
Estimate against measurement, compound 4: 1.1-fold (0.05 log units) above, and the stated range covers the measured number.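

Compound 4 gives a number in this assay, where compound 1 and compound 3 each hold only a limit of the assay. Methoxy in place of chloro on this aromatic carbon gives an at least 1.1-fold lower number from compound 3 to compound 4 (0.05 log units; that floor lies within the scatter), and hydrogen in place of bromo gives an at least 1.1-fold lower number from compound 1 to compound 4 (0.05 log units; that floor lies within the scatter). Neither step has a known full size because each starts from a limit: the limit of > 100000 nM in this assay, at which 2 of the 4 values shown sit.

The compounds shown leave open whether another group on this carbon, such as an amine or a carboxylic acid, would give a step beyond the scatter.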